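Trifluoromethylphenyl in Place of Benzyl on the Amine

The compounds below may be only part of what the source reports. "The series", "measured", "known", "first", "only" and "open" are said of these compounds alone.

Compound 1 `O=C1C=C(NCc2ccccc2)C(=O)c2c1nc1n2[C@H]2OC[C@@H](O)[C@H]2OC1`: > 8000 nM, a limit of the assay.
Compound 2 `O=C1C(NC2CCCC2)=CC(=O)c2c1nc1n2[C@H]2OC[C@@H](O)[C@H]2OC1`: > 16000 nM, a limit of the assay.
Compound 3 `O=C1C(N2CCCC2)=CC(=O)c2c1nc1n2[C@H]2OC[C@@H](O)[C@H]2OC1`: > 16000 nM, a limit of the assay.

In a functional assay on MCF7 cells (Homo sapiens) for inhibition, read by sulforhodamine B assay (on this read-out lower numbers stand for stronger inhibition and higher numbers for weaker inhibition), none of the three compounds gives a number. Compound 1 stands at the limit of > 8000 nM in this assay, at which 1 of the 3 values shown sits. Compound 2 sits at the limit of > 16000 nM in this assay, at which 2 of the 3 values shown sit. Compound 3 sits at that same limit.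

Compound 4 `O=C1C=C(Nc2ccc(C(F)(F)F)cc2)C(=O)c2c1nc1n2[C@H]2OC[C@@H](O)[C@H]2OC1` has not been measured. It differs from compound 1 by 4-(trifluoromethyl)phenyl in place of benzyl on an amine nitrogen. Among the compounds with values here, the only measured step, a step that the two limits leave unreadable from compound 2 to compound 3, concerns a different part of the shared core and cannot be read, so no measured step bears on this change. With compound 1 itself at a limit, no direction is readable. Compound 4 is therefore expected to stay near that limit, estimated at 10000 nM, within 3000 nM to 40000 nM. The expected step that the limit leaves unreadable from compound 1 to compound 4 lies within the scatter.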

Compound 4, half-maximal inhibitory concentration: > 4000 nM
Compound 4: a limit, no number; the forecaster's own chance of this, stated with the estimate: 70%; the middle value does not contradict the limit.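

Compound 1 and compound 4 each stop at a limit of the assay and give no number, so the step between them cannot be read. The compounds shown leave open whether 4-(trifluoromethyl)phenyl in place of benzyl changes inhibition at all.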